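The compounds below may be only part of what the source reports. "The series", "measured", "known", "first", "only" and "open" are said of these compounds alone.

Measured compounds:
compound 1, `C[C@@H]1CCCN1c1c(C#N)c2c(N)nc(Nc3cn[nH]c3)nc2n1C` — 6 nM
compound 2, `Cc1c(Nc2nc(N)c3c(C#N)c(N4CCC[C@H]4C)n(C)c3n2)cnn1CC1(O)COC1` — 10 nM
compound 3, `Cn1c(N)c(C#N)c2c(N)ncnc21` — 8560 nM

In an assay on isolated protein for inhibition of Leucine-rich repeat serine/threonine-protein kinase 2 variant G2019S (Homo sapiens), read by TR-FRET and LanthaScreen, with stated times of 50 min and 30 min, in the presence of a further agent that is not named here (on this read-out higher numbers stand for weaker inhibition and lower numbers for stronger inhibition), compound 1 gives 6 nM and stands at the low end of the three numbers. Compound 2, which carries a different group on the same pyrazole, gives 10 nM in this assay, and the gap between compound 1 and compound 2 lies within the usual scatter, so no order between them can be drawn. Compound 3, which lacks the whole pyrazolylamino arm and the 2-methylpyrrolidinyl group of the shared core, gives 8560 nM, far beyond the scatter from compound 1.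

The step from compound 1 to the not yet measured compound 4, `Cc1nn(C)cc1Nc1nc(N)c2c(C#N)c(N3CCC[C@H]3C)n(C)c2n1`, is a small one: 1,3-dimethyl-1H-pyrazol-4-yl in place of 1H-pyrazol-4-yl on a nitrogen on an aromatic ring. The aromatic amine nitrogen that joins the pyrazole to the core is kept; the pyrazole gains two methyl groups and loses its ring hydrogen-bond donor. Compound 2 shows that a substituted pyrazole on this nitrogen, including a methyl on the ring carbon, keeps the number close to that of compound 1 in this assay.

Compound 4 is therefore expected to give about 8 nM in this assay, with a range from 3 nM to 25 nM. The step of a 1.3-fold higher number from compound 1 to compound 4 (0.12 log units; within the scatter) is expected to remain within the scatter, with no clear direction.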

Compound 4, half-maximal inhibitory concentration: 30 nM
Compound 4: middle estimate off by 3.8-fold (0.57 log units), on the low side; the measured number lies above the stated range.
By their numbers in this assay, from the lowest: compounds 1 and 2 (each within the scatter of the next); then compound 4; then compound 3.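

In this assay, placing 1,3-dimethyl-1H-pyrazol-4-yl in place of 1H-pyrazol-4-yl on a nitrogen on an aromatic ring gives a 5.0-fold higher number from compound 1 to compound 4 (0.70 log units; beyond the scatter), so the number at this position does respond to what the pyrazole carries, though the step is a modest one. The change does several things at once: the group that leaves has 1 hydrogen-bond donor, the group that enters has 0 hydrogen-bond donors, and two methyl groups are added, so this single step cannot separate the contribution of each. No measurement is available that bears on why the number rises.

The compounds shown leave open whether a pyrazole bearing only one of the two methyl groups would give a step of the same size, and thus whether one methyl group or both go with the rise. They also leave open how the number would respond if a longer chain, such as an ethyl group or a hydroxyethyl group, took the place of either methyl group.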